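The source may report more compounds than this note shows. Statements on the series, on what has been measured and on what is new or still open speak of the compounds shown alone.

Working notes on the series, all read in a functional assay on A549 cells (Homo sapiens) for inhibition, read by MTT assay, with a stated time of 48 h; on this read-out lower numbers stand for stronger inhibition and higher numbers for weaker inhibition. Compound 1 `Cc1ccc(NC(=O)Nc2cccc(-c3cccc4[nH]nc(N)c34)c2)cc1Cl` gives 1750 nM, compound 2 `Nc1n[nH]c2cccc(-c3cccc(NC(=O)Nc4cccc(F)c4)c3)c12` gives 1360 nM and compound 3 `Nc1n[nH]c2cccc(-c3cccc(NC(=O)Nc4cc(C(F)(F)F)cc(C(F)(F)F)c4)c3)c12` gives 1510 nM. Compound 2 lies within the scatter of both others, so the three stand on one level and no ranking can be drawn among them.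

The next compound is compound 4 `COc1cccc(NC(=O)Nc2cccc(-c3cccc4[nH]nc(N)c34)c2)c1`, which carries methoxy in place of fluoro on an aromatic carbon, meta to a large group, relative to compound 2: methoxy in place of fluoro on an aromatic carbon.

Within the data shown here, one measured step bears directly on this aryl group: a 1.3-fold lower number from compound 1 to compound 2 (0.11 log units; within the scatter), with 3-fluorophenyl in place of 3-chloro-4-methylphenyl on an amide-type nitrogen. That step lies within the scatter. Compound 3 also differs from compound 2 on this aryl group, and the two stay within the scatter of each other, with compound 3 at 1510 nM. Among the measured compounds shown here, no methoxy compound has been measured yet, so the evidence for this particular group is indirect. With the aryl changes so far moving the number so little, no step beyond the scatter is expected.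

The estimated step is a 1.2-fold higher number from compound 2 to compound 4 (0.07 log units; within the scatter). For compound 4 the expected value is 1600 nM, with an estimated range of 800 nM to 3500 nM.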

Compound 4, half-maximal inhibitory concentration: 2490 nM
Compound 4: middle estimate off by 1.6-fold (0.19 log units), on the low side, and the stated range covers the measured number.
By their numbers in this assay, from the lowest: compounds 2, 3, 1 and 4 (each within the scatter of the next).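

In this assay, methoxy in place of fluoro on an aromatic carbon, meta to a large group, gives the widest step yet among the compounds that differ in one place (a 1.8-fold higher number from compound 2 to compound 4 (0.26 log units; within the scatter)), but that step still lies within the scatter, so this position accepts a hydrogen-bond acceptor and a larger group than fluoro without a measurable change. The comparison with the 3-chloro-4-methylphenyl compound reads the same way (a 1.4-fold higher number from compound 1 to compound 4 (0.15 log units; within the scatter)), which leaves compound 4 on one level with both compound 2 and compound 1, and the 3-methoxyphenyl group, the only oxygen-bearing aryl group shown, separates from neither of them. Nothing on hand offers any explanation of this result.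

It remains open whether any group on this aryl ring can move the number beyond the scatter, since every single-place step shown so far lies within it. An amine or a carboxylic acid at this same position, or a longer chain such as ethoxy in place of methoxy, would show whether the flat picture holds beyond the groups seen here.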